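This account rests on a few compounds, and the source may have more. Where it says the series, first, only, none or still open, it means among the compounds named here.

Measured so far:
compound 1, `N=C(NCc1ccccc1)[C@@H]1CCC(=O)N1Cc1ccccc1`, 27.9%
compound 2, `N=C(NCc1ccc(O)cc1)[C@@H]1CCC(=O)N1Cc1ccccc1`, 35.4%

Of the compounds shown here, two share one core and have been read in a functional assay on SH-SY5Y cells (Homo sapiens) for cytotoxicity, read by MTT assay, with stated times of 8 h, 30 min and 12 h, tested at 0.5 uM; on this read-out higher numbers stand for a stronger effect at the one concentration tested and lower numbers for a weaker effect. Compound 1 is `N=C(NCc1ccccc1)[C@@H]1CCC(=O)N1Cc1ccccc1`, and in this assay compound 1 gives 27.9%. Compound 2 is `N=C(NCc1ccc(O)cc1)[C@@H]1CCC(=O)N1Cc1ccccc1`, and in this assay compound 2 gives 35.4%. Within the data shown here, compound 2 therefore stands beside compound 1, the two numbers lying within the usual scatter of each other; the one step that joins them, a number 7.5 percentage points higher from compound 1 to compound 2 (within the scatter), is the only step on record.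

Compound 3 is `COc1ccc(CNC(=N)[C@@H]2CCC(=O)N2Cc2ccccc2)cc1`. It differs from compound 2 as methyl in place of hydrogen on an oxygen on an aromatic ring. Among the measured compounds shown here, no measured pair shows this change; the nearest comparison is the change at the same position of the outer ring, a number 7.5 percentage points higher from compound 1 to compound 2 (within the scatter), which stayed within the scatter. With so little to go on, compound 3 is expected to give a number close to that of compound 2, with a number 3.4 percentage points lower from compound 2 to compound 3 (within the scatter) as the expected step. Compound 3 is estimated at 32%, within a range of 18% to 46%.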

Compound 3, a percentage reported as activity, at one concentration (the size of the read-out at that concentration, not a potency): 23.6%
The estimate for compound 3 lay 8.4 percentage points above the measured number, within the range that was stated.
By their numbers in this assay, from the lowest: compounds 3, 1 and 2 (each within the scatter of the next, the first and the last beyond it).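

In this assay, among these compounds, methyl in place of hydrogen on the oxygen gives the first step on record at this position that goes beyond the scatter, and it is a modest one (a number 11.8 percentage points lower from compound 2 to compound 3 (beyond the scatter)). The methoxy group taken on its own, by contrast, stays within the scatter (a number 4.3 percentage points lower from compound 1 to compound 3 (within the scatter)), so compound 3 cannot be told apart from compound 1 on this read-out. The hydroxy and methoxy compounds therefore separate from each other, while neither separates from compound 1.

On these data alone, whether a longer chain on this oxygen, such as ethoxy, or an amine or a carboxylic acid in place of the hydroxy would read like compound 2 or like compound 3 stays open. No measurement at hand accounts for the gap between hydroxy and methoxy.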